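Dropping an amino group: from compound 3 to compound 4

The source may hold more compounds than are shown below. What is called first, only, known or untested is meant among the compounds shown, and "the series" means these compounds.

Of the compounds shown here, three that share one core have been tested in a functional assay on Hs-578T cells (Homo sapiens) for cytotoxicity, read by sulforhodamine B assay, with a stated time of 48 h; a higher number here means that more compound is tolerated, a lower number that less compound is tolerated. Compound 1 `ClCc1ccc(Cn2cnc3c(Cl)nc(Cl)nc32)cc1` carries two chloro groups on the core. In this assay compound 1 gives > 100000 nM, which is a limit of the assay rather than a number. Compound 2 `ClCc1ccccc1Cn1cnc2ncnc(Cl)c21` gives 66100 nM in this assay. Compound 3 `Nc1nc(Cl)c2ncn(Cc3cccc(CCl)c3)c2n1` gives > 100000 nM in this assay, again a limit and not a measured number. Compound 3 therefore stands at the limit, where two of the three values sit, as described by the limit of > 100000 nM in this assay, at which 2 of the 3 values shown sit. Because only a limit is known for compound 3, no direction of change can be read from it yet.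

Compound 4 `ClCc1cccc(Cn2cnc3c(Cl)ncnc32)c1` has not been measured. It differs from compound 3 in one place: hydrogen in place of amino on an aromatic carbon. Among the measured compounds shown here, no step between two measured compounds that differ in only one place is available to guide this change. Compound 2, which also lacks an amino group on the core, gives 66100 nM in this assay. Compound 4 is therefore expected to give about 80000 nM, somewhere between 30000 nM and 200000 nM. The expected step of an at least 1.2-fold lower number from compound 3 to compound 4 (0.09 log units; that floor lies within the scatter) is estimated as none beyond the usual scatter, or a small lowering at most.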

Compound 4, concentration lethal to 50% of the cells: 81300 nM
Beside the measured number, compound 4's estimate is 1.0-fold (0.01 log units) below it, within the range that was stated.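

In this assay, among the compounds shown here, hydrogen in place of amino on the aromatic carbon between two ring nitrogen atoms gives an at least 1.2-fold lower number from compound 3 to compound 4 (0.08 log units; that floor lies within the scatter), the first step that can be read at this position, and without the amino group compound 4 gives a real number rather than a limit. Compound 3 gives > 100000 nM, which is a limit of the assay and not a number. The true change could therefore lie within the usual scatter or well beyond it, and the step is only a floor set by a limit: the limit of > 100000 nM in this assay, at which 2 of the 4 values shown sit.

The compounds shown leave open how a methyl group, a methoxy group or a larger amine such as dimethylamino on that same carbon would read in this assay, so it is not yet known whether any group there other than amino and hydrogen would shift the number. Compound 1 and compound 2 each differ from compound 4 in more than one place, and no second example of this swap stands among the compounds shown, leaving open whether it would read the same way on another compound.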